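Homocysteine-chain acids: hydrazide, ester, nitrile

The source may report more compounds than this note shows. Statements on the series, on what has been measured and on what is new or still open speak of the compounds shown alone.

Measured so far:
compound 1, `NNC(=O)C(N)CCSCCCCC(=O)O`: 28%
compound 2, `COC(=O)C(N)CCSCCCCC(=O)O`: "not determined" (no result reported)

In an assay on isolated protein for inhibition of betaine--homocysteine S-methyltransferase 1 (Homo sapiens), with a stated time of 30 min, tested at 20 uM (a lower number here means less inhibition, a higher number more inhibition at the concentration tested (going by the name of the read-out)), compound 1 gives 28%. For the measured compounds named here, compound 2, `COC(=O)C(N)CCSCCCCC(=O)O`, gives "not determined" (no result reported) in this assay; it stands without a value, so nothing can be said of where it sits against compound 1, and no step between the two can be given.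

Compound 3 is `N#CC(N)CCSCCCCC(=O)O`. It differs from compound 2 in one place: cyano in place of methoxycarbonyl on a saturated chain carbon bound to an amine nitrogen and a saturated chain carbon. The rest of the chain, the amine and the terminal acid are unchanged.

With no value for compound 2, the step from compound 2 to compound 3 in this assay cannot be sized from the data; no step beyond the scatter is assumed in either direction. Going by the values given here, the only anchor is compound 1, whose reading of 28% sets the level seen for this chain with another group in the same place.

Compound 3 is expected to give about 25% in this assay, with a range of 5% to 50%.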

Compound 3, a percentage reported as inhibition, at one concentration (the size of the read-out at that concentration, not a potency): 9%
The estimate for compound 3 lay 16 percentage points above the measured number, and the stated range covers the measured number.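

In this assay, cyano in place of aminocarbamoyl on a saturated chain carbon bound to an amine nitrogen and a saturated chain carbon gives a number 19 percentage points lower from compound 1 to compound 3 (beyond the scatter). For the compounds shown here, this is the first readable step, and it shows that the read-out at the concentration tested depends on the group at this place, with the rest of the chain, the amine and the terminal acid held the same. Steps to or from compound 2 cannot be read, so the methoxycarbonyl group gives no third point at this place, and no supporting evidence bears on the step that can be read.

Going by these compounds alone, with only two values at this place, the series does not show whether the size of the group, the type of carbonyl group or some other feature tracks with the read-out. Also open, on these data alone, is where a carboxylic acid or a primary amide at this place would fall relative to compound 1 and compound 3, and what a longer chain on the terminal acid side would do to either compound.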